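Replacing 1-methyl-1H-indol-3-yl in compound 2 with 4-methoxyphenyl

The source may report more compounds than this note shows. Statements on the series, on what has been measured and on what is new or still open speak of the compounds shown alone.

Within the data shown here, in a functional assay on HeLa cells (Homo sapiens) for inhibition, read by CCK-8 assay, with a stated time of 48 h (a lower number here means a stronger inhibitor, a higher number a weaker inhibitor), compound 1 `COc1cc(-c2ccnc3cc(-c4ccc5cc[nH]c5c4)nn23)cc(OC)c1OC` gives 125 nM and compound 2 `COc1cc(-c2ccnc3cc(-c4cn(C)c5ccccc45)nn23)cc(OC)c1OC` gives 399 nM, so compound 2 is the weaker inhibitor of the two measured so far. Compound 3 `COc1ccc(-c2cc3nccc(-c4cc(OC)c(OC)c(OC)c4)n3n2)cc1` keeps the core and the other substituent of compound 2 and differs at one place, with 4-methoxyphenyl in place of 1-methyl-1H-indol-3-yl on an aromatic carbon. Among the measured compounds shown here, only one measured step bears on this place, a 3.2-fold higher number from compound 1 to compound 2 (0.50 log units; beyond the scatter), and it shows that a swap of group here can shift the number modestly. For the measured compounds named here, no measured compound carries 4-methoxyphenyl at this place, so the direction is uncertain, and a small step with a slight lean towards weaker inhibition is expected. The expected change is a 1.3-fold higher number from compound 2 to compound 3 (0.10 log units; within the scatter). For compound 3 the estimate is 500 nM, with an expected range of 130 nM to 2200 nM.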

Compound 3, half-maximal inhibitory concentration: 373 nM
Estimate against measurement, compound 3: 1.3-fold (0.13 log units) above; measured number inside the range.
By their numbers in this assay, from the lowest: compound 1; then compounds 3 and 2 (each within the scatter of the next).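

In this assay, the single 4-methoxyphenyl ring and the two-ring 1-methyl-1H-indol-3-yl group give numbers that cannot be told apart, with a 1.1-fold lower number from compound 2 to compound 3 (0.03 log units; within the scatter), so a fused five-membered ring is not required to reach this level at this place. Compound 1 remains the strongest of the three, with a 3.0-fold higher number from compound 1 to compound 3 (0.47 log units; beyond the scatter), so its 1H-indol-6-yl group stands apart from both of the other groups. Nothing available explains these results.

It remains open whether the edge of compound 1 depends on the hydrogen on its indole nitrogen or on where the indole is attached, as these two features change together across the compounds shown. Going by these compounds, how a pyridine ring, or an amine or carboxylic acid on the phenyl ring, would behave at this place also remains open.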